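Amino in place of nitro on the dimethoxyphenyl partner

The source may hold more compounds than are shown below. What is called first, only, known or untested is meant among the compounds shown, and "the series" means these compounds.

Within the data shown here, compound 1 `COc1ccc(-c2snnc2-c2cc(OC)c(OC)c(OC)c2)cc1[N+](=O)[O-]` is the only member of the set with a numerical result: in an ADME assay on HMEC-1 cells (Homo sapiens) for antiproliferative activity (on this read-out higher numbers stand for weaker inhibition and lower numbers for stronger inhibition), compound 1 gives 26.4 nM. Compound 2 `COc1cc(-c2nnsc2-c2ccc([N+](=O)[O-])cc2)cc(OC)c1OC` is reported only as a limit of the assay; in this assay compound 2 gives > 1000 nM. Among the measured compounds shown here, the only evidence given on the measured values is the limit of > 1000 nM in this assay, at which 1 of the 3 values shown sits. Compound 3 `COc1cc(-c2nnsc2-c2ccc(Cl)cc2)cc(OC)c1OC` has no single number in this assay; for compound 3 the entry is "not determined" (no result reported). For the measured compounds named here, no step between two measured compounds that differ in a single place is available, so compound 1 stands alone as the reference point for the series.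

Compound 4 `COc1ccc(-c2snnc2-c2cc(OC)c(OC)c(OC)c2)cc1N` is the next compound to be measured. Its change from compound 1 is amino in place of nitro on an aromatic carbon. Nothing in the measured set shows what an amino in place of a nitro does here, and the shared core of compound 1 is otherwise kept. In the absence of a measured step, the working expectation is a step of no size beyond the scatter, in either direction; the step that this estimate means is a 1.1-fold higher number from compound 1 to compound 4 (0.06 log units; within the scatter), expected to fall within the scatter. Compound 4 is therefore expected to give about 30 nM in this assay, with a range from 8 nM to 120 nM, the width reflecting that only compound 1 anchors the estimate.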

Compound 4, half-maximal inhibitory concentration: 2.5 nM
Compound 4: middle estimate off by 12-fold (1.08 log units), on the high side; the whole stated range lies above it.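

Amino in place of nitro, on an aromatic carbon ortho to a methoxy group and meta to a large group, gives in this assay an 11-fold lower number from compound 1 to compound 4 (1.02 log units; beyond the scatter) as the first step that can be read in this series. The earlier compounds shown here gave no view of this position, and this step shows that the read-out responds strongly to what sits there, with the shared core unchanged and the lower number on the amino side. The change takes out nitro and puts in amino, a smaller group by the heavy-atom count that carries a hydrogen-bond donor, but no measured property among the data shown ties either feature to the step.

Open, from the compounds shown here alone, is whether the lower number depends on amino itself or would also appear with a hydroxyl, a methylamino group or an acetamide on the same carbon, and whether the methoxy group ortho to it is needed. Compound 2 stands only as a limit of the assay and compound 3 has no result, so neither adds a step at this position.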